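This account rests on a few compounds, and the source may have more. Where it says the series, first, only, none or still open, it means among the compounds named here.

Of the compounds shown here, three have been measured in a physicochemical assay for lipophilicity (a lower number here means a more polar compound, a higher number a more lipophilic compound), and a fourth is still to be measured. Compound 1 `CC(=O)Nc1ccc(OC(=S)Nc2ccc(Sc3ccc(C(F)(F)F)cc3)cc2)cc1` gives 5.96. Compound 2 `Oc1ccc(OC(=S)Nc2ccc(Sc3ccc(C(F)(F)F)cc3)cc2)cc1` gives 6.66. Compound 3 `Oc1ccc(OC(=S)Nc2ccc(Nc3ccc(C(Cl)(Cl)Cl)cc3)cc2)cc1` gives 6.79. Compound 4 `CC(=O)Nc1ccc(OC(=S)Nc2ccc(Nc3ccc(C(Cl)(Cl)Cl)cc3)cc2)cc1` has no value yet in this assay.

Compound 2 and compound 1 share one core and differ in a single place: acetamido in place of hydroxy on an aromatic carbon. That change made a number 0.70 log units lower from compound 2 to compound 1 (beyond the scatter). Compound 2 and compound 3 are built on different cores; the difference between the two cores is not broken down here, and their values in this assay lie close together, within the usual scatter.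

Among the measured compounds shown here, compound 4 is related to compound 3 by the same change as the one from compound 2 to compound 1: acetamido in place of hydroxy on an aromatic carbon. Because the earlier change made a number 0.70 log units lower from compound 2 to compound 1 (beyond the scatter), a step of similar size is expected on the core of compound 3. The expected step is a number 0.70 log units lower from compound 3 to compound 4 (beyond the scatter). On that basis compound 4 is estimated at 6.09, with a likely range from 5.6 to 6.6.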

Compound 4, partition coefficient: 6.07
Estimate against measurement, compound 4: 0.02 log units above, within the range that was stated.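

In this assay the swap of hydroxy for acetamido on an aromatic carbon gave a number 0.72 log units lower from compound 3 to compound 4 (beyond the scatter), and on the other core it gave a number 0.70 log units lower from compound 2 to compound 1 (beyond the scatter), so the step kept its direction and much the same size when carried from one core to the other. For these two pairs, then, the 4-hydroxyphenyl to 4-acetamidophenyl change behaves as a nearly constant step, but two pairs are too few to show that it would hold on any further core in the series. Nothing given here explains why the step has this size.

From the compounds shown here alone, it remains open whether an amine or a carboxylic acid in place of the hydroxy, or a longer chain in place of the acetamido, would give a similarly steady step across the two cores. The trifluoromethyl and trichloromethyl groups also change together with the rest of the core, so their separate contributions cannot be read from these compounds.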